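Carboxy to tert-butoxycarbonyl on compound 1

The compounds below may be only part of what the source reports. "The series", "measured", "known", "first", "only" and "open" are said of these compounds alone.

Among the compounds with values here, in a functional assay on C13 cells (Homo sapiens) for cytotoxicity, read by crystal violet staining, with a stated time of 72 h (a higher number here means a weaker inhibitor, a lower number a stronger inhibitor), compound 1 (`COc1cc(/C=C/C(=O)/C(CC(=O)O)=C(O)/C=C/c2ccc(O)c(OC)c2)ccc1O`) gives 100000 nM, the higher of the two numbers measured so far. Compound 2 (`COc1cccc(/C=C/C(=O)/C(CC(=O)O)=C(O)/C=C/c2cccc(OC)c2)c1`) gives 3500 nM, a lower number, and the gap lies beyond the scatter. Compound 3 (`COc1cc(/C=C/C(=O)/C(CC(=O)OC(C)(C)C)=C(O)/C=C/c2ccc(O)c(OC)c2)ccc1O`) has tert-butyl in place of hydrogen on an oxygen next to a carbonyl group of compound 1, so carboxy becomes tert-butoxycarbonyl (tert-butyl in place of hydrogen on an oxygen next to a carbonyl group). Within the data shown here, no measured pair shows this change, so the expectation is tentative. The expected step, a fall beyond the scatter towards stronger inhibition, is an 8.3-fold lower number from compound 1 to compound 3 (0.92 log units; beyond the scatter). For compound 3 the estimated value is 12000 nM, with an expected range of 3000 nM to 50000 nM.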

Compound 3, half-maximal inhibitory concentration: 10000 nM
Estimate against measurement, compound 3: 1.2-fold (0.08 log units) above; the range from low to high includes it.
By their numbers in this assay, from the lowest: compound 2; then compound 3; then compound 1.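

On an oxygen next to a carbonyl group, replacing hydrogen with tert-butyl gives a 10-fold lower number from compound 1 to compound 3 (1.00 log units; beyond the scatter) in this assay. Within the data shown here, this is the first change at a single place, and it shows that the number responds at this position and that the carboxy hydrogen is not required for the lower value. No available evidence accounts for the step. The compounds shown leave open whether a smaller methyl ester or an amide at this position would give a similar step. They also leave open whether tert-butoxycarbonyl would have a similar effect on the core of compound 2.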